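A few compounds are considered here, and "the series" means these few. Any claim that something is new, unique, unknown or untested is made for them only; others in the source may bear on it.

Working notes on the series. Compound 3 `CC(=O)Nc1cccc(NC(=O)COc2ccc3c(=O)ccoc3c2)c1` stands highest of the three numbers in an assay on isolated protein for inhibition of Rho-associated protein kinase 1 (Homo sapiens), read by scintillation counting, radiometric assay and 33P incorporation, with a stated time of 40 min, in the presence of a further agent that is not named here (a lower number here means a stronger inhibitor, a higher number a weaker inhibitor), at 2500 nM; compound 1 `COc1ccc(OCC(=O)Nc2cccc(NC(=O)c3ccc(N(C)C)cc3)c2)cc1F` gives 1820 nM, and compound 2 `CN(C)c1ccc(C(=O)Nc2cccc(NC(=O)COc3ccc4c(c3)OCCC4=O)c2)cc1` gives 144 nM. Compound 4 `CCc1ccc(C(=O)Nc2cccc(NC(=O)COc3ccc4c(=O)ccoc4c3)c2)cc1` differs from compound 3 by 4-ethylphenyl in place of methyl on a carbonyl carbon. Within the data shown here, no measured step changes that position: the single measured step, a 13-fold lower number from compound 1 to compound 2 (1.10 log units; beyond the scatter), alters the group on the oxygen on the saturated carbon, not the carbonyl. Compounds 2 and 3 differ in two places at once, so their values show only that an aryl carbonyl accompanied the lower number. The change in compound 4 is therefore expected to move the number down by about a 3.1-fold lower number from compound 3 to compound 4 (0.49 log units; beyond the scatter), a modest step, with compound 4 estimated at 800 nM (range 250 nM to 2500 nM).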

Compound 4, half-maximal inhibitory concentration: 235 nM
Compound 4: the middle estimate sits 3.4-fold (0.53 log units) above what was measured; the measured number lies below the stated range.
By their numbers in this assay, from the lowest: compounds 2 and 4 (each within the scatter of the next); then compounds 1 and 3 (each within the scatter of the next).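

Swapping methyl for 4-ethylphenyl on the carbonyl carbon gives an 11-fold lower number from compound 3 to compound 4 (1.03 log units; beyond the scatter) in this assay, the first measured step at this position. The carbonyl substituent alone therefore carries a large change, which compounds 2 and 3, differing in two places at once, could not isolate. Nothing at hand explains this step.

Whether the aromatic ring or the ethyl on it accounts for the step remains open. A plain phenyl, a cyclohexyl or a carboxylic acid on the ring, each on the same carbonyl carbon, would help separate these contributions.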